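Replacing a carbonyl-bearing side chain with a plain benzyl

A few compounds are considered here, and "the series" means these few. Any claim that something is new, unique, unknown or untested is made for them only; others in the source may bear on it.

Three compounds share one core and differ only in the group carried on the saturated chain carbon bound to an oxygen on a saturated carbon. Compound 1 `Cc1nn(-c2ncnc3nc[nH]c23)c2c1C(OCC(=O)c1ccc(F)cc1)CC(=O)N2` carries a (4-fluorophenyl)carbonyl there; in a functional assay on HEK293 cells for agonist activity at G-protein coupled receptor 39 (Homo sapiens), read by scintillation proximity assay and inositol phosphate accumulation, with a stated time of 75 min (a higher number here means that more compound is needed for the effect, a lower number that less compound is needed), compound 1 gives 973 nM, the lowest of the three numbers. Compound 2 `Cc1nn(-c2ncnc3nc[nH]c23)c2c1C(OCc1ccc(C(C)C)cc1)CC(=O)N2` carries a 4-isopropylphenyl instead and gives 1690 nM; the change is a 1.7-fold higher number from compound 1 to compound 2 (0.24 log units; within the scatter). Compound 3 `Cc1nn(-c2ncnc3nc[nH]c23)c2c1C(C(=O)N(C)c1ccccc1)CC(=O)N2` has a quite different side chain and gives 5220 nM, a number further from compound 1 than the usual scatter allows.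

Compound 4 `Cc1nn(-c2ncnc3nc[nH]c23)c2c1C(OCCc1ccccc1)CC(=O)N2` is not yet measured. It differs from compound 1 by benzyl in place of (4-fluorophenyl)carbonyl on a saturated chain carbon bound to an oxygen on a saturated carbon. For the measured compounds named here, the one measured step that resembles this change is the one from compound 1 to compound 2, where the (4-fluorophenyl)carbonyl was also swapped for an aromatic group without a carbonyl, and that step was within the scatter. On that basis the step is expected to be small, with at most a mildly higher number, so a 1.5-fold higher number from compound 1 to compound 4 (0.19 log units; within the scatter) is the estimate. For compound 4 the expected value in this assay is 1500 nM, with a likely range from 600 nM to 3800 nM.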

Compound 4, half-maximal effective concentration: 40 nM
Compound 4: middle estimate off by 38-fold (1.57 log units), on the high side, and the stated range ends above it.
By their numbers in this assay, from the lowest: compound 4; then compounds 1 and 2 (each within the scatter of the next); then compound 3.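

The group carried here matters far more than compounds 1 and 2 alone suggested: in this assay, benzyl in place of (4-fluorophenyl)carbonyl gives a 24-fold lower number from compound 1 to compound 4 (1.39 log units; beyond the scatter), although the earlier swap for 4-isopropylphenyl, which also removed the carbonyl, stayed within the scatter. Losing the carbonyl therefore does not by itself produce the large drop, and the comparison between the two carbonyl-free side chains gives a 42-fold lower number from compound 2 to compound 4 (1.63 log units; beyond the scatter), so the precise shape of the aromatic side chain counts. Compound 3, with its quite different side chain, lies even further away, with phenethyloxy in place of methyl(phenyl)carbamoyl giving a 130-fold lower number from compound 3 to compound 4 (2.12 log units; beyond the scatter).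

No independent measurement bears on why the number falls so sharply. The carbonyl and the fluorine leave together between compound 1 and compound 4. On these data alone, their separate contributions remain unknown, and it also remains open whether a longer chain such as 3-phenylpropyl, or an amine in the chain, would lower the number further or lose what phenethyl gained.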